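The source may report more compounds than this note shows. Statements on the series, on what has been measured and on what is new or still open speak of the compounds shown alone.

Three compounds have been measured in an ADME assay on microsomes from liver (Rattus norvegicus, strain Sprague-Dawley) for metabolic stability, read by LC-MS, with a stated time of 15 min, tested at 20 uM; on this read-out higher numbers stand for a more stable compound and lower numbers for a less stable compound:

compound 1 `Cc1cccc(OC(=O)c2coc(-c3ccccc3)n2)c1C` gives 4.9%;
compound 2 `Cc1ccccc1OC(=O)c1coc(-c2ccccc2)n1` gives 13.4%;
compound 3 `Cc1ccc(COC(=O)c2coc(-c3ccccc3)n2)c(C)c1` gives 16.9%.

Compound 4 `Cc1ccccc1COC(=O)c1coc(-c2ccccc2)n1` has not yet been measured. It differs from compound 3 in one place: hydrogen in place of methyl on an aromatic carbon. The same kind of change is seen between two measured compounds, (hydrogen in place of methyl on an aromatic carbon), where the step was a number 8.5 percentage points higher from compound 1 to compound 2 (within the scatter). The surroundings of the place are not identical: in compound 1 the place is ortho to a methyl group and meta to a large group, while in compound 3 it is meta to a methyl group and para to a large group. How the core of compound 1 and the core of compound 3 differ is not broken down here. Compound 3 lies beyond the scatter above compound 1, while its gap to compound 2 lies within the scatter. Given the earlier step, the step from compound 3 to compound 4 is expected to be small, a number 4.1 percentage points higher from compound 3 to compound 4 (within the scatter). Compound 4 is accordingly estimated at 21%, with a likely range from 8% to 36%.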

Compound 4, percent of the compound remaining: 10.9%
Beside the measured number, compound 4's estimate is 10.1 percentage points above it; the measured number falls inside the stated range.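

In this assay, putting hydrogen in place of methyl on an aromatic carbon gives a number 6 percentage points lower from compound 3 to compound 4 (within the scatter) on the core of compound 3. Set beside the earlier step, the same change does not carry over from one core to the other as a single fixed shift: the same change on two cores in this assay, a number 8.5 percentage points higher (within the scatter) from compound 1 to compound 2 and a number 6 percentage points lower (within the scatter) from compound 3 to compound 4, 14.5 percentage points apart, beyond the scatter of two such steps. Each step on its own stays within the scatter, however, and two pairs of compounds do not show a real effect on either core or give a rule for the series.

The compounds shown leave open what a methoxy group or a chlorine atom at this place would do on either core. They also leave open how an amide in place of the ester would read here.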